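Hydrazone aryl swaps and THP-1 cytotoxicity

The compounds below may be only part of what the source reports. "The series", "measured", "known", "first", "only" and "open" are said of these compounds alone.

Among the compounds with values here, compound 3 `COc1ccccc1-c1nnc(-c2ccc(C(=O)N/N=C/c3ccccc3[N+](=O)[O-])cc2)o1` gives 161000 nM in an ADME assay on THP-1 cells (Homo sapiens) for cytotoxicity (a higher number here means a weaker inhibitor, a lower number a stronger inhibitor), the second highest of the three numbers so far. Compound 1 `COc1ccccc1-c1nnc(-c2ccc(C(=O)N/N=C/c3cc(O)ccc3O)cc2)o1` gives 100000 nM and compound 2 `COc1ccccc1-c1nnc(-c2ccc(C(=O)N/N=C/c3cccc(O)c3)cc2)o1` gives 398000 nM. Compound 4 `COc1ccccc1-c1nnc(-c2ccc(C(=O)N/N=C/c3ccc(F)cc3)cc2)o1` carries the change (4-fluorophenyl in place of 2-nitrophenyl on a carbon with a double bond to nitrogen). Both earlier aryl swaps on the carbon with a double bond to nitrogen bear on it: a 1.6-fold higher number from compound 1 to compound 3 (0.21 log units; within the scatter) and a 2.5-fold lower number from compound 2 to compound 3 (0.39 log units; beyond the scatter), and the hydroxy removal a 4.0-fold higher number from compound 1 to compound 2 (0.60 log units; beyond the scatter) concerns the same ring. All stay modest, with compound 3 sitting between compound 1 and compound 2. Within the data shown here, no measured compound carries a ring without donors or acceptors there, so the direction is open. The expected outcome is a step within the scatter or a modest rise, a 1.2-fold higher number from compound 3 to compound 4 (0.09 log units; within the scatter). Compound 4 is therefore estimated at 200000 nM, ranging from 80000 nM to 500000 nM.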

Compound 4, half-maximal inhibitory concentration: 427000 nM
For compound 4 the middle estimate is 2.1-fold (0.33 log units) below the measured one; the range from low to high includes it.
By their numbers in this assay, from the lowest: compounds 1 and 3 (each within the scatter of the next); then compounds 2 and 4 (each within the scatter of the next).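

The swap to 4-fluorophenyl gives a 2.7-fold higher number from compound 3 to compound 4 (0.42 log units; beyond the scatter) in this assay and a 4.3-fold higher number from compound 1 to compound 4 (0.63 log units; beyond the scatter) on the same carbon with a double bond to nitrogen. With a 1.1-fold higher number from compound 2 to compound 4 (0.03 log units; within the scatter) in the same assay, a ring without hydrogen-bond donors or acceptors stands level with the 3-hydroxyphenyl ring, so their presence alone does not sort the series, and compound 2 goes against any such reading. Nothing available explains this split into two pairs.

As far as these compounds go, whether an amine or a carboxylic acid on this ring would join compounds 1 and 3 or compounds 2 and 4 remains open.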